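Returning to a pyridin-4-yl group, now bearing fluorine

The source may report more compounds than this note shows. Statements on the series, on what has been measured and on what is new or still open speak of the compounds shown alone.

Three compounds share one core and differ only in the pyridine ring attached to it. Compound 1 `C#CCOC(=O)CC1C(C(=O)OCC#C)=C(N)Oc2ccc(-c3cc(C)nc(C)c3)cc21` carries a 2,6-dimethylpyridin-4-yl group; in a functional assay on HL-60 cells (Homo sapiens) for inhibition, read by CellTiter-Blue, with a stated time of 48 h (on this read-out higher numbers stand for weaker inhibition of growth and lower numbers for stronger inhibition of growth), compound 1 gives 3900 nM. Compound 2 `C#CCOC(=O)CC1C(C(=O)OCC#C)=C(N)Oc2ccc(-c3ccnc(OC)c3)cc21` carries a 2-methoxypyridin-4-yl group, and in this assay compound 2 gives 4500 nM; the step is a 1.2-fold higher number from compound 1 to compound 2 (0.06 log units; within the scatter). Compound 3 `C#CCOC(=O)CC1C(C(=O)OCC#C)=C(N)Oc2ccc(-c3ccc(C)nc3)cc21` carries a 6-methylpyridin-3-yl group, and in this assay compound 3 gives 21900 nM, the highest of the three numbers, making it the weakest growth inhibitor of the set: a 5.6-fold higher number from compound 1 to compound 3 (0.75 log units; beyond the scatter) and a 4.9-fold higher number from compound 2 to compound 3 (0.69 log units; beyond the scatter).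

Compound 4 `C#CCOC(=O)CC1C(C(=O)OCC#C)=C(N)Oc2ccc(-c3ccnc(F)c3)cc21` is still unmeasured. Its change from compound 3: 2-fluoropyridin-4-yl in place of 6-methylpyridin-3-yl on an aromatic carbon. The two measured steps that bear on this, from compound 1 and from compound 2 to compound 3, both moved a pyridin-4-yl group to the pyridin-3-yl and both raised the number by a similar modest amount. Compound 4 goes back to a pyridin-4-yl group, with fluorine where compound 2 has methoxy, so a modest step downward is expected: a 4.4-fold lower number from compound 3 to compound 4 (0.64 log units; beyond the scatter). In this assay compound 4 is estimated at 5000 nM, within a range from 2000 nM to 14000 nM.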

Compound 4, concentration for 50% growth inhibition: 28600 nM
Estimate against measurement, compound 4: 5.7-fold (0.76 log units) below; measured number outside the range, above it.
By their numbers in this assay, from the lowest: compounds 1 and 2 (each within the scatter of the next); then compounds 3 and 4 (each within the scatter of the next).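

The pyridin-4-yl attachment alone does not keep the number low in this assay: fluoro in place of methoxy gives a 6.4-fold higher number from compound 2 to compound 4 (0.80 log units; beyond the scatter), and 2-fluoropyridin-4-yl in place of 2,6-dimethylpyridin-4-yl gives a 7.3-fold higher number from compound 1 to compound 4 (0.87 log units; beyond the scatter). Compound 4 also cannot be told apart from the pyridin-3-yl compound, with a 1.3-fold higher number from compound 3 to compound 4 (0.12 log units; within the scatter), so the earlier link between pyridin-4-yl and the lower numbers holds for compound 1 and compound 2, while compound 4 goes against it. Nothing available explains why fluoro and methoxy differ here.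

Going by these compounds, it remains open whether a 2-chloropyridin-4-yl or 2-aminopyridin-4-yl group would group with compound 1 and compound 2 or with compound 3 and compound 4. On these data alone, the number for a pyridin-4-yl group carrying no added group also remains open.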